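Amide substituent change on a vitamin D receptor agonist scaffold

The source may hold more compounds than are shown below. What is called first, only, known or untested is meant among the compounds shown, and "the series" means these compounds.

Measured so far in an assay on HL-60 cells for agonist activity at vitamin D3 receptor (Homo sapiens), read by microscopy, with a stated time of 96 h; on this read-out lower numbers stand for an effect already at smaller amounts and higher numbers for an effect only at larger amounts of compound:
compound 1 `C#CCNC(=O)c1ccc(C(CC)(CC)c2ccc(OCC(=O)C(C)(C)C)c(C)c2)n1CC` gives 2200 nM
compound 2 `CCN(CC)CCNC(=O)c1ccc(C(CC)(CC)c2ccc(OCC(O)C(C)(C)C)c(C)c2)n1CC` gives 110 nM
compound 3 `C#CCNC(=O)c1ccc(C(CC)(CC)c2ccc(OCC(O)C(C)(C)C)c(C)c2)n1CC` gives 240 nM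

Compound 3 stands second among these three numbers: in this assay compound 3 sits a step from compound 2 and further from compound 1. The two measured steps are a 9.2-fold lower number from compound 1 to compound 3 (0.96 log units; beyond the scatter) and a 2.2-fold higher number from compound 2 to compound 3 (0.34 log units; beyond the scatter).

Compound 4 `CCn1c(C(=O)N(C)c2ccccc2)ccc1C(CC)(CC)c1ccc(OCC(O)C(C)(C)C)c(C)c1` differs from compound 3 at the amide end: methyl(phenyl)amino in place of propargylamino on a carbonyl carbon. Going by the values given here, of the measured steps, only the one between compound 2 and compound 3 touches this end of the molecule, and there the exchange of one amide substituent for another shifted the number by a 2.2-fold higher number from compound 2 to compound 3 (0.34 log units; beyond the scatter); the step from compound 1 to compound 3 concerns the other end and does not bear on this change. Among the compounds with values here, no measured pair shows an aromatic ring on the amide nitrogen, so the direction is open. A modest shift is therefore expected for compound 4, a 1.5-fold higher number from compound 3 to compound 4 (0.16 log units; within the scatter), and its value in this assay is estimated at 350 nM, within 100 nM to 1200 nM.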

Compound 4, half-maximal effective concentration: 6400 nM
Estimate against measurement, compound 4: 18-fold (1.26 log units) below; the measured number lies above the stated range.
By their numbers in this assay, from the lowest: compound 2; then compound 3; then compound 1; then compound 4.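

In this assay the amide end proves far less tolerant than the earlier exchange there suggested, with methyl(phenyl)amino in place of propargylamino on a carbonyl carbon giving a 27-fold higher number from compound 3 to compound 4 (1.43 log units; beyond the scatter) and the same group in place of (2-(diethylamino)ethyl)amino giving a 58-fold higher number from compound 2 to compound 4 (1.76 log units; beyond the scatter). Both steps are far larger than the earlier one at this end, a 2.2-fold higher number from compound 2 to compound 3 (0.34 log units; beyond the scatter), so the two amines compared before say little about the reach of this position. The change removes the amide hydrogen and brings in a six-membered aromatic ring in one step, and no supporting data explain the result.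

On these data alone, what stays open is whether the higher number goes with the phenyl ring or with the loss of the amide hydrogen. Phenylamino and dimethylamino on the same carbonyl carbon would separate the two.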